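Trimethoxyphenyl amides: halogen versus methoxy on the benzyl ring

The source may report more compounds than this note shows. Statements on the series, on what has been measured and on what is new or still open speak of the compounds shown alone.

Measured compounds:
- compound 1 `COc1ccc(CNc2cc(OC)c(OC)c(OC)c2)cc1F` gives 32200 nM
- compound 2 `C/C=C/C(=O)N(Cc1ccc(OC)c(Cl)c1)c1cc(OC)c(OC)c(OC)c1` gives 1420 nM
- compound 3 `C/C=C/C(=O)N(Cc1ccc(OC)c(OC)c1)c1cc(OC)c(OC)c(OC)c1` gives 32800 nM

In a functional assay on HCT-116 cells (Homo sapiens) for inhibition, read by MTT assay, with a stated time of 48 h (on this read-out lower numbers stand for stronger inhibition and higher numbers for weaker inhibition), compound 3 stands with the highest number of the three. Its nearest neighbour is compound 1, whose value sits within the scatter of it, so no order between the two can be read. Among the measured compounds shown here, the one clear separation is to compound 2: the single change of methoxy in place of chloro on an aromatic carbon gave a 23-fold higher number from compound 2 to compound 3 (1.36 log units; beyond the scatter), a large step toward weaker inhibition.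

Compound 4 `C/C=C/C(=O)N(Cc1ccc(OC)c(F)c1)c1cc(OC)c(OC)c(OC)c1` has not yet been measured. It differs from compound 3 by fluoro in place of methoxy on an aromatic carbon.

For the measured compounds named here, the only measured step that bears on this position is the one from compound 2 to compound 3, where removing the chloro in favour of methoxy cost a great deal. Putting fluoro in its place returns a halogen to that carbon, so a move in the opposite direction, toward a lower number in this assay, is expected. Whether fluoro recovers the full chloro value is not known from these three compounds, so a step smaller than the reverse of the measured one is estimated: a 7.3-fold lower number from compound 3 to compound 4 (0.86 log units; beyond the scatter). For compound 4 a value of 4500 nM is expected, within 1500 nM to 14000 nM.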

Compound 4, half-maximal inhibitory concentration: 1160 nM
For compound 4 the middle estimate is 3.9-fold (0.59 log units) above the measured one; measured number below the stated range.
By their numbers in this assay, from the lowest: compounds 4 and 2 (each within the scatter of the next); then compounds 1 and 3 (each within the scatter of the next).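

In this assay, the step of a 28-fold lower number from compound 3 to compound 4 (1.45 log units; beyond the scatter) shows that this carbon, ortho to a methoxy group, gives the same kind of large response to fluoro as the earlier step of a 23-fold higher number from compound 2 to compound 3 (1.36 log units; beyond the scatter) gave to chloro and methoxy, read in the opposite direction. The two halogens cannot be told apart at this position, with a 1.2-fold lower number from compound 2 to compound 4 (0.09 log units; within the scatter), so the weak value of compound 3 now goes with methoxy on this carbon, and not with the loss of chloro alone, across these three compounds. Among the compounds shown here, with fluoro held in both compounds, the step of a 28-fold lower number from compound 1 to compound 4 (1.44 log units; beyond the scatter) also gives the first single-change reading of (prop-1-en-1-yl)carbonyl in place of hydrogen on the nitrogen, and it is a large one.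

The compounds shown offer no independent data that could explain either large step. Still open, as far as these compounds go, is how a hydroxyl group, a nitrile or a trifluoromethyl group would read on this carbon, and whether a longer chain or a terminal amine on the acyl group would hold the value of compound 4.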